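The compounds below may be only part of what the source reports. "The series", "measured", "known", "first", "only" and "open" are said of these compounds alone.

The measured compounds:

Compound 1 `C#CCSc1nnc(C)n1N1C(=O)c2ccccc2C1=O`: in a functional assay on MKN-45 cells (Homo sapiens) for cytotoxicity, read by MTT assay, with a stated time of 48 h (a lower number here means a stronger inhibitor, a higher number a weaker inhibitor), compound 1 gives > 200000 nM, which is a limit of the assay and not a number.
Compound 2 `CCCc1nnc(SCc2ccccc2)n1N1C(=O)c2ccccc2C1=O`: in this assay compound 2 gives > 200000 nM, again a limit of the assay.
Compound 3 `COc1cc(-c2nnc(SC)n2N2C(=O)c3ccccc3C2=O)cc(OC)c1OC`: in this assay compound 3 gives > 200000 nM, also a limit of the assay.

All three share the same core and differ in the groups attached at two places on it. Compound 3 therefore stands exactly where the other two stand: at the limit, with no number of its own. the limit of > 200000 nM in this assay, at which 3 of the 3 values shown sit, sums up the whole picture. For the measured compounds named here, no step between measured compounds can be read off, since every value is a limit rather than a number.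

Compound 4 `COc1cc(-c2nnc(SCC(=O)c3ccc(F)cc3)n2N2C(=O)c3ccccc3C2=O)cc(OC)c1OC` differs from compound 3 by (4-fluorophenyl)carbonyl in place of hydrogen on a saturated chain carbon bound to a sulfur. Nothing measured shows whether adding a group on the chain carbon bound to a sulfur moves the read-out. Compound 1 carries a larger group bound to the sulfur and still gives only a limit. Compound 2 likewise carries a larger group there and still gives only a limit. The step of an at least 1.3-fold lower number from compound 3 to compound 4 (0.12 log units; that floor lies within the scatter) is therefore expected to be small, if any. Compound 4 is estimated at 150000 nM, within a range from 40000 nM to 600000 nM.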

Compound 4, half-maximal inhibitory concentration: 126000 nM
Compound 4: the middle estimate sits 1.2-fold (0.08 log units) above what was measured; the range from low to high includes it.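

For the compounds shown here, compound 4 is the only compound here whose result in this assay is a number rather than a limit, so a measurable read-out is possible with (4-fluorophenyl)carbonyl on the saturated chain carbon bound to a sulfur. As far as these compounds go, the change gives an at least 1.5-fold lower number from compound 3 to compound 4 (0.20 log units; that floor lies within the scatter), but this is only a floor, and the true size of the step remains unknown. One measured number does not change the overall picture, which is still dominated by compounds at the top of the assay's range: the limit of > 200000 nM in this assay, at which 3 of the 4 values shown sit.

The compounds shown do not reveal which part of the entering group matters, such as the fluorine, the carbonyl or the aromatic ring, and they offer no comparison with a plain phenylcarbonyl group, a chlorine on the ring, or an amine or carboxylic acid at the end of the chain. From the compounds shown here alone, it also remains open whether (4-fluorophenyl)carbonyl would give a number at the same place on compound 1 or compound 2, which differ from compound 3 at the other substituted place on the shared core.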